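Where a single methyl lands on the core

A few compounds are considered here, and "the series" means these few. Any claim that something is new, unique, unknown or untested is made for them only; others in the source may bear on it.

Measured in a functional assay on SF-295 cells (Homo sapiens); a lower number here means a stronger inhibitor of growth, a higher number a weaker inhibitor of growth:
Compound 1 `COc1ccc(-c2cc(O)c3cccnc3n2)cc1`: 64600 nM
Compound 2 `COc1ccc(-c2cc(O)c3cc(C)cnc3n2)cc1`: 5250 nM

Of these two numbers, compound 1 has the higher, which makes it the weaker growth inhibitor of the pair. Compound 3 `COc1ccc(-c2cc(O)c3ccc(C)nc3n2)cc1` has not yet been measured. It differs from compound 1 by a single change: methyl in place of hydrogen on an aromatic carbon. Its methyl stands next to the ring nitrogen, on a different carbon from the one that carries the methyl in compound 2.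

Among the measured compounds shown here, only one measured step bears on this change, the same exchange of hydrogen for methyl made at that other carbon: a 12-fold lower number from compound 1 to compound 2 (1.09 log units; beyond the scatter). That single step points towards a lower number, but nothing yet shows how a methyl next to the ring nitrogen behaves. A drop in the same direction is therefore expected in this assay, probably smaller and far less certain, and it may not clear the scatter. The expected step is a 4.0-fold lower number from compound 1 to compound 3 (0.61 log units; beyond the scatter). For compound 3 the estimated value is 16000 nM, with an expected range of 3500 nM to 65000 nM.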

Compound 3, concentration for 50% growth inhibition: 89100 nM
For compound 3 the middle estimate is 5.6-fold (0.75 log units) below the measured one; measured number above the stated range.
By their numbers in this assay, from the lowest: compound 2; then compounds 1 and 3 (each within the scatter of the next).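

At the carbon next to the ring nitrogen, exchanging hydrogen for methyl gives a 1.4-fold higher number from compound 1 to compound 3 (0.14 log units; within the scatter) in this assay and so leaves the growth-inhibition number of the core unchanged within the usual scatter. The earlier step, a 12-fold lower number from compound 1 to compound 2 (1.09 log units; beyond the scatter) in this assay for the same exchange at another carbon, showed only that a methyl can matter on this core; taken together, the two steps show that the outcome depends on which carbon carries it, a contrast that rests on these two pairs alone. Nothing available here accounts for this difference between the two carbons.

On these data alone, it remains open whether a methyl at this carbon is simply tolerated or whether other groups placed there, such as an ethyl chain, an amine or a chlorine atom, would move the number in either direction. The compounds shown also leave open whether the contrast between the two carbons holds on a core that carries something other than the methoxy-bearing aromatic ring of compound 1.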